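This account rests on a few compounds, and the source may have more. Where it says the series, first, only, none or still open, it means among the compounds named here.

Measured compounds in a functional assay on RXF 393 cells (Homo sapiens) for inhibition, read by sulforhodamine B assay, with a stated time of 48 h; a lower number here means a stronger inhibitor of growth, a higher number a weaker inhibitor of growth:
compound 1 `COc1cc(-c2cc(/C=C/C(=O)c3ccc(Cl)c(Cl)c3)[nH]n2)cc(OC)c1OC` gives 2700 nM
compound 2 `COc1ccc(C(=O)/C=C/c2cc(-c3cc(OC)c(OC)c(OC)c3)n[nH]2)cc1` gives 1270 nM

Compound 2 stands lowest of the two numbers in this assay, with compound 1 the nearest. Going by the values given here, the single step available, a 2.1-fold lower number from compound 1 to compound 2 (0.33 log units; beyond the scatter), was modest and beyond the scatter. Compound 3 `COc1cc(-c2cc(/C=C/C(=O)c3ccc(F)c(F)c3)[nH]n2)cc(OC)c1OC` is compound 2 with 3,4-difluorophenyl in place of 4-methoxyphenyl on a carbonyl carbon. The measured step bears on this change but runs the opposite way, so a modest rise back toward the number of compound 1 is expected in this assay; the estimated step is a 1.7-fold higher number from compound 2 to compound 3 (0.24 log units; within the scatter). Compound 3 is therefore expected near 2200 nM, within a range of 1000 nM to 4800 nM.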

Compound 3, concentration for 50% growth inhibition: 2050 nM
Compound 3: middle estimate off by 1.1-fold (0.03 log units), on the high side; measured number inside the range.
By their numbers in this assay, from the lowest: compounds 2, 3 and 1 (each within the scatter of the next, the first and the last beyond it).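

On a carbonyl carbon, 3,4-difluorophenyl gives a number that the assay cannot separate from either earlier compound in this assay, with a 1.6-fold higher number from compound 2 to compound 3 (0.21 log units; within the scatter) and a 1.3-fold lower number from compound 1 to compound 3 (0.12 log units; within the scatter). The 3,4-difluorophenyl group therefore stays within the scatter of both 3,4-dichlorophenyl and 4-methoxyphenyl, although compound 1 and compound 2 remain separated beyond it. No available evidence accounts for these numbers. Still open, going by these compounds, is how a phenyl ring carrying a dimethylamino group or a carboxylic acid would read at this position. On these data alone, a non-aromatic group such as a longer alkyl chain also remains open there.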